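Small Ring Swap on a Weakly Cytotoxic Core

The compounds below may be only part of what the source reports. "The series", "measured", "known", "first", "only" and "open" are said of these compounds alone.

- Compound 1 `C[C@H]1CC[C@@H]2[C@@H](OC(=O)[C@]23CC(c2c(Cl)cccc2Cl)=NO3)[C@]2(C)C(=O)C=C[C@@]12O` gives 56000 nM
- Compound 2 `C[C@H]1CC[C@@H]2[C@@H](OC(=O)[C@]23CC(c2ccc(Cl)cc2)=NO3)[C@]2(C)C(=O)C=C[C@@]12O` gives 49000 nM
- Compound 3 `COc1ccc(C2=NO[C@]3(C2)C(=O)O[C@@H]2[C@H]3CC[C@H](C)[C@]3(O)C=CC(=O)[C@@]23C)cc1OC` gives 25000 nM
- Compound 4 `Cc1ccccc1C1=NO[C@]2(C1)C(=O)O[C@@H]1[C@H]2CC[C@H](C)[C@]2(O)C=CC(=O)[C@@]12C` has not yet been measured

These compounds share one core and differ in a single ring group. In a functional assay on PC-3 cells (Homo sapiens) for cytotoxicity, read by sulforhodamine B assay, with a stated time of 48 h (a lower number here means a stronger inhibitor, a higher number a weaker inhibitor), compound 3 stands clearly apart only from compound 1, with a 2.2-fold lower number from compound 1 to compound 3 (0.35 log units; beyond the scatter) as the evidence. Against compound 2 no order can be told, given a 2.0-fold lower number from compound 2 to compound 3 (0.29 log units; within the scatter) as the measured gap.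

The next change is 2-methylphenyl in place of 3,4-dimethoxyphenyl on a carbon with a double bond to nitrogen and it puts 2-methylphenyl in place of 3,4-dimethoxyphenyl on a carbon with a double bond to nitrogen. For the measured compounds named here, no measured compound carries 2-methylphenyl. The closest guides are the swaps already seen, and a 1.1-fold lower number from compound 1 to compound 2 (0.06 log units; within the scatter) shows how little one such swap can move the number. Those two steps to compound 3 were also small, so read in reverse they point to a modest rise on leaving 3,4-dimethoxyphenyl. In this assay the expected outcome is a 1.5-fold higher number from compound 3 to compound 4 (0.18 log units; within the scatter) as an estimated step. Compound 4 is expected to give 38000 nM with 17000 nM to 80000 nM as the estimated range.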

Compound 4, half-maximal inhibitory concentration: 10000 nM
For compound 4 the middle estimate is 3.8-fold (0.58 log units) above the measured one; measured number below the stated range.
By their numbers in this assay, from the lowest: compound 4; then compounds 3, 2 and 1 (each within the scatter of the next, the first and the last beyond it).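

In this assay the ring group on the carbon with a double bond to nitrogen can move the number further than the earlier swaps showed: 2-methylphenyl gives a 2.5-fold lower number from compound 3 to compound 4 (0.40 log units; beyond the scatter) and a 4.9-fold lower number from compound 2 to compound 4 (0.69 log units; beyond the scatter) and also a 5.6-fold lower number from compound 1 to compound 4 (0.75 log units; beyond the scatter). For the compounds shown here, compound 4 is thus the only compound here whose steps to all three others lie beyond the scatter, although a smaller group with no hydrogen-bond acceptors was not expected to do better than 3,4-dimethoxyphenyl. Nothing available explains why this group gives the lowest number.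

Whether the methyl group matters remains open, since a plain phenyl ring is not among the compounds shown. Also open, on these data alone, is how a 2-ethylphenyl group, or a phenyl ring carrying an amine or a carboxylic acid, would compare with compound 4.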